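The compounds below may be only part of what the source reports. "The series", "measured", "known", "first", "only" and "open" are said of these compounds alone.

Measured compounds:
compound 1, `O=C1CSC(c2cccc(Cl)c2)N1CCN1CCCCC1`, 20%
compound 2, `O=C1CSC(c2cccc(O)c2)N1CCN1CCCCC1`, 13%

Both compounds were tested in an ADME assay on Vero cells (Chlorocebus sabaeus) for cytotoxicity, read by neutral red uptake, tested at 1575 ug/mL; on this read-out lower numbers stand for a stronger effect and higher numbers for a weaker effect at the one concentration tested. Within the data shown here, compound 2 stands at 13%, and its only neighbour on the numbers is compound 1 at 20%; the step of a number 7 percentage points lower from compound 1 to compound 2 (within the scatter) lies within the scatter, so the two cannot be told apart on this read-out. Compound 3, `O=C1CSC(c2ccc(O)cc2)N1CCN1CCCCC1`, has not yet been measured in this assay. It differs from compound 2 in one place: 4-hydroxyphenyl in place of 3-hydroxyphenyl on a saturated ring carbon. Among the measured compounds shown here, the one measured step, a number 7 percentage points lower from compound 1 to compound 2 (within the scatter), swapped a chloro for a hydroxy on the aromatic carbon and stayed within the scatter; no measured step moves the hydroxy from one ring position to another, so nothing here speaks for a shift beyond the scatter in either direction. The step of a number 2 percentage points higher from compound 2 to compound 3 (within the scatter) is therefore expected to be none beyond the scatter. Compound 3 is expected to give about 15% in this assay, between 3% and 30%.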

Compound 3, a percentage reported as activity, at one concentration (the size of the read-out at that concentration, not a potency): 12%
Compound 3: the middle estimate sits 3 percentage points above what was measured, and the stated range covers the measured number.
By their numbers in this assay, from the lowest: compounds 3, 2 and 1 (each within the scatter of the next).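

Setting 4-hydroxyphenyl in place of 3-hydroxyphenyl on the saturated ring carbon gives, in this assay, a number 1 percentage points lower from compound 2 to compound 3 (within the scatter) and so tests for the first time where the hydroxy sits on the aromatic ring; on this read-out, the two hydroxy isomers cannot be told apart. Setting 4-hydroxyphenyl in place of 3-chlorophenyl at the same ring carbon gives a number 8 percentage points lower from compound 1 to compound 3 (within the scatter) and so shows that changing the substituent and its place on the aromatic ring together also yields no separation in this assay. No measured information is available to account for this lack of separation.

The compounds shown leave open whether an amine or a carboxylic acid in place of the hydroxy on the aromatic ring would give a number beyond the scatter. They also leave open whether a morpholine ring or a longer chain in place of the group of 8 heavy atoms would separate from these three compounds, and whether other concentrations would distinguish the three at all.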